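Efficacy Expectation for Compound 3 from Two Full Agonists

The source may hold more compounds than are shown below. What is called first, only, known or untested is meant among the compounds shown, and "the series" means these compounds.

Measured compounds:
Compound 1 `CC(C)(C)OC(=O)N1CCC(O[C@H]2CC[C@H](Oc3ccc(S(C)(=O)=O)cc3)CC2)CC1` — 115%
Compound 2 `C[C@H](CF)OC(=O)N1CCC(O[C@H]2CC[C@H](Oc3cnc(S(C)(=O)=O)cn3)CC2)CC1` — 108%

Both measured compounds were tested in a functional assay on isolated protein for agonist activity at Glucose-dependent insulinotropic receptor (Homo sapiens), read by HTRF and cAMP accumulation; on this read-out lower numbers stand for smaller maximal responses and higher numbers for larger maximal responses. Compound 1 gives 115% in this assay, and compound 2 gives 108%. On the two numbers shown, compound 2 carries the lower figure, but its only neighbour, compound 1, sits within the usual scatter of it, so the two maximal responses cannot be told apart; both read as full responses relative to the control.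

Compound 3 `CC(F)Cc1nc(CN2CCC(O[C@H]3CC[C@H](Oc4cnc(S(C)(=O)=O)cn4)CC3)CC2)no1` has not yet been measured. It differs from compound 2 as follows: a group of 10 heavy atoms (6 carbon, 2 nitrogen, 1 oxygen, 1 fluorine; one five-membered aromatic ring with 3 hetero atoms) in place of a group of 7 heavy atoms (4 carbon, 2 oxygen, 1 fluorine; no ring), on an amine nitrogen in a ring

Within the data shown here, no pair of measured compounds differing in a single place is available, so no measured step can guide the expectation. What is known is that compound 2, with its seven-heavy-atom group on the ring amine nitrogen, reaches 108% in this assay, and compound 1, with a different group at that position, reaches 115%. With both at full response, the exchange is expected to give a step of a number 3 percentage points lower from compound 2 to compound 3 (within the scatter), that is, none beyond the scatter. Compound 3 is therefore estimated at 105% in this assay, within a range from 85% to 125%.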

Compound 3, largest response reached (Emax), in percent of the reference or control that the assay uses: 97%
Estimate against measurement, compound 3: 8 percentage points above; the measured number falls inside the stated range.
By their numbers in this assay, from the lowest: compound 3; then compounds 2 and 1 (each within the scatter of the next).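

In this assay, (5-(2-fluoropropyl)-1,2,4-oxadiazol-3-yl)methyl in place of the group without a ring, on an amine nitrogen in a ring, gives a number 11 percentage points lower from compound 2 to compound 3 (beyond the scatter), and this is the only step shown that can be read at this position, as compound 1 and compound 2 differ in more than one place. The earlier numbers could not show whether the maximal response depends on this position at all; this modest step shows that it does, although compound 3 still reaches 97% with a five-membered aromatic ring in the group. Nothing in the data shown accounts for the size or direction of this step.

Among these compounds, the single step changes the whole group at once, so it leaves open whether the oxadiazole ring, the methyl link to the amine nitrogen or the fluorine of the side chain matters, and a plain propyl chain in place of the 2-fluoropropyl would bear on that question. From the compounds shown here alone, it is also open whether the same exchange would give a similar step on the core of compound 1.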